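This account rests on a few compounds, and the source may have more. Where it says the series, first, only, none or still open, it means among the compounds named here.

In a functional assay on A549 cells (Homo sapiens) for antiproliferative activity, read by MTT assay, with a stated time of 72 h (on this read-out lower numbers stand for stronger inhibition and higher numbers for weaker inhibition), compound 1 (`COc1ccc(-c2ncnn2-c2cc(OC)c(OC)c(OC)c2)cc1`) gives 520 nM. Compound 2 (`COc1cccc(-c2ncnn2-c2cc(OC)c(OC)c(OC)c2)c1`) reaches only a limit, > 10000 nM. The change from 4-methoxyphenyl to 3-methoxyphenyl therefore gives an at least 19-fold higher number from compound 1 to compound 2 (1.28 log units; beyond the scatter). Compound 3 (`COc1cc(-n2ncnc2-c2cccc([N+](=O)[O-])c2)cc(OC)c1OC`) also stands only at a limit, > 10000 nM. With nitro in place of methoxy, the result is a step that the two limits leave unreadable from compound 2 to compound 3.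

Compound 4 (`COc1cc(-n2ncnc2-c2cccc(Cl)c2)cc(OC)c1OC`) carries chloro in place of nitro on an aromatic carbon, meta to a large group: chloro in place of nitro on an aromatic carbon. Compound 2 and compound 3, each with its group meta to a large group, share (the limit of > 10000 nM in this assay, at which 2 of the 3 values shown sit). Among the measured compounds shown here, no measured step gives the size of a change among such groups, so the comparison with compound 3 rests on a limit alone. Compound 4 is expected to stay weak in this assay, with at most a modest move towards lower numbers and a real chance of another limit. The estimated change is an at least 1.2-fold lower number from compound 3 to compound 4 (0.09 log units; that floor lies within the scatter). The estimate for compound 4 is 8000 nM, with an expected range of 2500 nM to 20000 nM.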

Compound 4, half-maximal inhibitory concentration: > 10000 nM
Compound 4: only a limit was reported; the forecaster's own chance of this, stated with the estimate: 60%; at least 1.2-fold (0.09 log units) between middle value and limit.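

In this assay compound 4 stands at a limit, > 10000 nM, so chloro is a third group at this place, after methoxy and nitro, that yields no number. The steps among compound 2, compound 3 and compound 4 cannot be read, while 3-chlorophenyl in place of 4-methoxyphenyl gives an at least 19-fold higher number from compound 1 to compound 4 (1.28 log units; beyond the scatter). Methoxy, nitro and chloro, each meta to a large group, therefore cannot be told apart here, and the series now gathers at one reading: the limit of > 10000 nM in this assay, at which 3 of the 4 values shown sit.

Open, going by these compounds, is whether the gap to compound 1 follows the place or the group, which a 4-chlorophenyl or 4-nitrophenyl analogue would separate. Also open, on these data alone, is whether an amino or hydroxyl group meta to a large group would give a value rather than a limit.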